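A few compounds are considered here, and "the series" means these few. Any claim that something is new, unique, unknown or untested is made for them only; others in the source may bear on it.

So far, two compounds have been tested for harm to cells. In an ADME assay on Vero cells (Chlorocebus sabaeus) for cytotoxicity, read by resazurin assay, with a stated time of 72 h (on this read-out higher numbers stand for weaker inhibition and lower numbers for stronger inhibition), compound 1 `O=C(CCN1CCN(c2ccc([N+](=O)[O-])cc2)CC1)c1ccc(F)c(Br)c1` gives 256000 nM as its value. Compound 2 `O=C(CCN1CCN(c2ccc(F)cc2)CC1)c1ccc(F)c(Cl)c1` gives 185000 nM as its value, which places it within the usual scatter of compound 1, so the two numbers cannot be told apart. Both are read here as a single level of effect on the cells.

Compound 3 `O=C(CCN1CCN(c2ccc([N+](=O)[O-])cc2)CC1)c1ccc(F)c(Cl)c1` has not been measured yet. It arises from compound 2 through one change, (nitro in place of fluoro on an aromatic carbon), which puts nitro in place of fluoro on an aromatic carbon and turns a 4-fluorophenyl into a 4-nitrophenyl. For the measured compounds named here, no measured pair shows this change on its own, so there is no direct step to lean on. Going by the values given here, the one hint is compound 1, which also carries a 4-nitrophenyl and gives 256000 nM as its value, within the scatter of compound 2. A small rise in the number is expected, estimated as a 1.2-fold higher number from compound 2 to compound 3 (0.09 log units; within the scatter), and this stays within the scatter. For compound 3 the expected value is 230000 nM with an estimated range from 120000 nM to 420000 nM as the likely span of the measurement.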

Compound 3, half-maximal inhibitory concentration: 116000 nM
Estimate against measurement, compound 3: 2.0-fold (0.30 log units) above; measured number below the stated range.
By their numbers in this assay, from the lowest: compounds 3, 2 and 1 (each within the scatter of the next, the first and the last beyond it).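

For the compounds shown here, putting nitro in place of fluoro, para to a large group, gives a 1.6-fold lower number from compound 2 to compound 3 (0.20 log units; within the scatter) in this assay and so offers the first direct look at this change: although nitro brings three heavy atoms and two hydrogen-bond acceptors where fluoro brought none, the two compounds cannot be told apart on this read-out. Chloro in place of bromo on an aromatic carbon, with the 4-nitrophenyl kept, gives a 2.2-fold lower number from compound 1 to compound 3 (0.34 log units; beyond the scatter), a modest step and the only one here that lies beyond the scatter, so this second place in the molecule, rather than the 4-fluorophenyl to 4-nitrophenyl swap, carries the one readable difference. Nothing available explains why either step has the size it has.

From the compounds shown here alone, whether other groups in place of the nitro, such as an amine or a carboxylic acid, would also stay within the scatter of compound 2 remains open. Going by these compounds, it is also open whether chloro in place of bromo would give a step of similar size alongside a 4-fluorophenyl, or how a methyl group would compare at that same place.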